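Replacing the (ethoxycarbonyl)amino group of compound 2

The source may report more compounds than this note shows. Statements on the series, on what has been measured and on what is new or still open speak of the compounds shown alone.

In a functional assay on HCT-116 cells (Homo sapiens) for inhibition, read by MTT assay, with a stated time of 72 h (a higher number here means that more compound is tolerated, a lower number that less compound is tolerated), compound 1 (`Cc1ccc(S(=O)(=O)n2c(C3(O)C=CC(=O)C=C3)cc3ccccc32)cc1`) gives < 10 nM, which is a limit of the assay. Among the compounds with values here, compound 2 (`CCOC(=O)Nc1ccc(S(=O)(=O)n2c(C3(O)C=CC(=O)C=C3)cc3ccccc32)cc1`) gives 295 nM, the only exact number so far. Compound 3 (`COC(=O)CCc1ccc(S(=O)(=O)n2c(C3(O)C=CC(=O)C=C3)cc3ccccc32)cc1`) carries 2-(methoxycarbonyl)ethyl in place of (ethoxycarbonyl)amino on an aromatic carbon. Within the data shown here, the one measured step at that place, an at least 29-fold higher number from compound 1 to compound 2 (1.46 log units; beyond the scatter), is large and starts from the limit, so it guides only loosely. A moderate fall is expected, estimated as a 3.0-fold lower number from compound 2 to compound 3 (0.47 log units; beyond the scatter). Compound 3 is expected at 100 nM, with an estimated range of 25 nM to 350 nM.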

Compound 3, concentration lethal to 50% of the cells: 20 nM
The estimate for compound 3 lay 5.0-fold (0.70 log units) above the measured number; measured number below the stated range.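

In this assay, the step shows a 15-fold lower number from compound 2 to compound 3 (1.17 log units; beyond the scatter): at this position, a group with the same heavy-atom count as (ethoxycarbonyl)amino, but without its hydrogen-bond donor, need not keep the number high. Set against the methyl group, the new chain gives an at least 2.0-fold higher number from compound 1 to compound 3 (0.30 log units; that floor lies within the scatter), so compound 3 cannot be ordered against compound 1 from this floor. The value of compound 1, < 10 nM, is a limit: the limit of < 10 nM in this assay, at which 1 of the 3 values shown sits.

Going by these compounds, what remains open is whether the nitrogen with its hydrogen goes with the higher number of compound 2, and how a carboxylic acid or an amine at the end of the chain would read.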